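Removing One Methyl From Compound 1

The source may hold more compounds than are shown below. What is called first, only, known or untested is meant among the compounds shown, and "the series" means these compounds.

Compound 1 `Cc1ccc(C23CCC(=O)N2CCCO3)c(C)c1` was tested in a functional assay on the whole organism (Central nervous system) with Mus musculus as the target (a lower number here means that less compound is needed, a higher number that more compound is needed for the effect), where compound 1 gives 150 mg/kg. Compound 2 `O=C1CCCC2(c3ccccc3)OCCCN12` gives 150 mg/kg in this assay, so compound 1 stands level with compound 2 within the scatter.

Compound 3 `Cc1ccc(C23CCC(=O)N2CCCO3)cc1` differs from compound 1 by hydrogen in place of methyl on an aromatic carbon. Since compound 1 gives 150 mg/kg and compound 2 gives 150 mg/kg, no step beyond the scatter is expected here. Compound 3 is therefore estimated at 150 mg/kg, with a range from 75 mg/kg to 300 mg/kg. The expected step of no change at the digits printed from compound 1 to compound 3 (within the scatter) is essentially none.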

Compound 3, dose for half-maximal effect: 160 mg/kg
Compound 3: middle estimate off by 1.1-fold (0.03 log units), on the low side, within the range that was stated.
By their numbers in this assay, from the lowest: compounds 1, 2 and 3 (each within the scatter of the next).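

In this assay, replacing the methyl on the aromatic carbon ortho to a large group with hydrogen gives a 1.1-fold higher number from compound 1 to compound 3 (0.03 log units; within the scatter), so this single change leaves the number inside the usual scatter. The methyl at this position is therefore not needed to hold the dose at this level. No further measurement bears on why this is so.

Open, from the compounds shown here alone, is whether this position tolerates only small changes, or whether an amine, a carboxylic acid or a longer chain there would move the number. The compounds shown also leave open what the remaining methyl of compound 3 contributes.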